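Replacing 2-Fluorobenzyl with 3-Hydroxybenzyl on a Shared Core

A few compounds are considered here, and "the series" means these few. Any claim that something is new, unique, unknown or untested is made for them only; others in the source may bear on it.

In a functional assay on KARPAS-299 cells (Homo sapiens) for cytotoxicity, read by XTT assay, with a stated time of 72 h (a lower number here means a stronger inhibitor, a higher number a weaker inhibitor), compound 1 `Cn1cc(-c2cnc3[nH]cc(-c4cnn(Cc5ccccc5F)c4)c3c2)cn1` gives 2090 nM. Within the data shown here, compound 2 `Cn1cc(-c2cnc3[nH]cc(-c4cnn(Cc5ccc(F)cc5)c4)c3c2)cn1`, the only other compound measured so far, gives 1780 nM. These two numbers lie within the usual scatter of repeated measurements, so they cannot be ranked against each other.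

Compound 3 `Cn1cc(-c2cnc3[nH]cc(-c4cnn(Cc5cccc(O)c5)c4)c3c2)cn1` keeps the core of compound 1 and changes one group, with 3-hydroxyphenyl in place of 2-fluorophenyl on a saturated chain carbon bound to an aromatic nitrogen.

Among the measured compounds shown here, the one measured step at this place is a 1.2-fold lower number from compound 1 to compound 2 (0.07 log units; within the scatter), with 4-fluorophenyl in place of 2-fluorophenyl. That step is within the scatter, but it offers only partial guidance, as the fluorine remains. For the measured compounds named here, no measured compound carries the 3-hydroxyphenyl group, so the data give no firm direction. No step beyond the scatter is therefore expected in this assay, although the uncertainty is wide. The expected change is a 1.2-fold lower number from compound 1 to compound 3 (0.06 log units; within the scatter). Compound 3 is estimated at 1800 nM, with an expected range from 600 nM to 5500 nM.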

Compound 3, half-maximal inhibitory concentration: 3360 nM
Compound 3: middle estimate off by 1.9-fold (0.27 log units), on the low side; the measured number falls inside the stated range.
By their numbers in this assay, from the lowest: compounds 2, 1 and 3 (each within the scatter of the next).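

In this assay, putting 3-hydroxyphenyl on a saturated chain carbon bound to an aromatic nitrogen gives a 1.6-fold higher number from compound 1 to compound 3 (0.21 log units; within the scatter) and also a 1.9-fold higher number from compound 2 to compound 3 (0.28 log units; within the scatter). The group that enters carries 1 hydrogen-bond donor and 1 hydrogen-bond acceptor, where 2-fluorophenyl carries 0 of each, and this exchange of a fluorine-bearing ring for a hydroxyl-bearing one still produces no step beyond the scatter, so the three compounds cannot be ranked against one another. Nothing available here explains these numbers or links them to any property of the groups.

All three groups shown are six-membered aromatic rings of carbon only, so it remains open whether a ring bearing an amine or a carboxylic acid, or a longer chain between the ring and the aromatic nitrogen, would give a step beyond the scatter. All three numbers also come from this assay alone, so these compounds cannot show whether the same exchange would leave the number just as unresolved on a different core.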